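Hydroxy for Ethyl, Carried From One Core to Another

The compounds below may be only part of what the source reports. "The series", "measured", "known", "first", "only" and "open" are said of these compounds alone.

Measured compounds:
compound 1 `CC[C@H](C)[C@H](NC(=O)CN(c1nc(Cl)nc2[nH]cnc12)C1CC1)C(=O)O` gives 36%
compound 2 `CC[C@H](C)[C@H](NC(=O)CN(c1ncnc2c1ncn2C1CCCCO1)C1CC1)C(=O)OCc1ccccc1` gives 27.4%
compound 3 `C[C@@H](O)[C@H](NC(=O)CN(c1nc(Cl)nc2[nH]cnc12)C1CC1)C(=O)O` gives 30.1%

All three were tested in a functional assay on the whole organism (Tail, strain ICR) with Mus musculus as the target, in the tail flick test, with a stated time of 60 min, at a dose of 25 umol/kg by the oral route; a lower number here means a weaker effect, a higher number a stronger effect of the compound at the dose given. Compound 3 differs from compound 1 by one change, (hydroxy in place of ethyl on a saturated chain carbon bound to two saturated chain carbons), and the step of a number 5.9 percentage points lower from compound 1 to compound 3 (within the scatter) lies within the scatter. Compound 2 carries a different core; the difference between the two cores is not broken down here, and its value stands within the scatter of both compound 1 and compound 3.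

Compound 4 `C[C@@H](O)[C@H](NC(=O)CN(c1ncnc2c1ncn2C1CCCCO1)C1CC1)C(=O)OCc1ccccc1` is not yet measured. It differs from compound 2 by hydroxy in place of ethyl on a saturated chain carbon bound to two saturated chain carbons, the same change as from compound 1 to compound 3, at the same place. Because the step of a number 5.9 percentage points lower from compound 1 to compound 3 (within the scatter) was small, the step of a number 5.4 percentage points lower from compound 2 to compound 4 (within the scatter) is expected to be of similar size. Compound 4 is therefore estimated at 22%, between 10% and 34%.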

Compound 4, a percentage reported as activity, at one dose (the size of the read-out at that dose, not a potency): 28.4%
For compound 4 the middle estimate is 6.4 percentage points below the measured one; the measured number falls inside the stated range.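

On the core of compound 2, hydroxy in place of ethyl gives, in this assay, a number 1 percentage points higher from compound 2 to compound 4 (within the scatter). Set beside the step on the core of compound 1, the change shows no measurable dependence on the core: the same change on two cores in this assay, a number 5.9 percentage points lower (within the scatter) from compound 1 to compound 3 and a number 1 percentage points higher (within the scatter) from compound 2 to compound 4, 6.9 percentage points apart, within the scatter of two such steps

This shows that on neither core did the change move the read-out beyond the scatter at this one dose and time; it does not show that the two cores truly respond alike, and small steps like these could hide a real difference.

The compounds shown leave open whether an amine or a longer chain on the same saturated chain carbon would move the read-out beyond the scatter. They also leave open how the change behaves at other doses or times.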